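This account rests on a few compounds, and the source may have more. Where it says the series, first, only, none or still open, it means among the compounds named here.

Measured so far:
compound 1 `Cc1cnn(C(=O)NCc2ccc(OCc3ccccc3)cc2)c1`: 1000 nM
compound 2 `O=C(NCc1ccc(OCc2ccccc2)cc1)n1cccn1`: 900 nM
compound 3 `Cc1cnn(C(=O)N(C)CCN(C)Cc2cccc(OCc3ccccc3)c2)c1`: 4100 nM

All three were tested in an assay on membranes from brain for binding affinity to Monoglyceride lipase (Mus musculus), read by fluorescence, with stated times of 1 h and 30 min; on this read-out lower numbers stand for stronger inhibition and higher numbers for weaker inhibition. In this assay compound 1 gives 1000 nM and compound 2 gives 900 nM. The two differ in one place only, and that difference is hydrogen in place of methyl on an aromatic carbon. The step between them is a 1.1-fold lower number from compound 1 to compound 2 (0.05 log units; within the scatter), so on this pair the change leaves the number essentially where it was.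

Compound 3 gives 4100 nM, the highest number of the three. It differs from compound 1 in more than one place, and the difference between the two cores is not broken down here. Compound 4 `CN(CCN(C)C(=O)n1cccn1)Cc1cccc(OCc2ccccc2)c1` has not yet been measured. It stands to compound 3 as compound 2 stands to compound 1: the difference is hydrogen in place of methyl on an aromatic carbon, the same change at a place described in exactly the same words, so it can be called the same change rather than merely the same kind.

The expectation for compound 4 rests on that single earlier example. Because the step of a 1.1-fold lower number from compound 1 to compound 2 (0.05 log units; within the scatter) lay within the scatter, the step from compound 3 to compound 4 is expected to be similarly small, a 1.1-fold lower number from compound 3 to compound 4 (0.04 log units; within the scatter). Compound 4 is therefore estimated at 3700 nM, with a likely range from 1500 nM to 9000 nM. What the assay actually reports for compound 4 remains to be seen.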

Compound 4, half-maximal inhibitory concentration: 4600 nM
Beside the measured number, compound 4's estimate is 1.2-fold (0.09 log units) below it, within the range that was stated.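

In this assay, putting 1H-pyrazol-1-yl in place of 4-methyl-1H-pyrazol-1-yl gives a 1.1-fold higher number from compound 3 to compound 4 (0.05 log units; within the scatter) and so leaves the number essentially where it was, as the same change did on the core of compound 1. Set side by side, the two results agree: the same change on two cores in this assay, a 1.1-fold lower number (0.05 log units; within the scatter) from compound 1 to compound 2 and a 1.1-fold higher number (0.05 log units; within the scatter) from compound 3 to compound 4, 1.2-fold (0.10 log units) apart, within the scatter of two such steps. Within the data shown here, this shows that, on these two cores, the methyl on the aromatic carbon can be exchanged for hydrogen with no change that stands out from ordinary repeat-to-repeat variation, so the earlier result carried over; it does not show that the methyl never matters, since two cores are only two examples, and a small step on both says nothing about a third core or about any other test.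

Only methyl and hydrogen appear on this aromatic carbon of the five-membered ring among the compounds shown, so it stays open whether a longer chain such as ethyl, a halogen such as chlorine, or an amine there would also leave the number in place. On these data alone, it also stays open whether any group at this carbon could bring the number down on either core, rather than leave it where it is.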